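A Pyrazole Amide Joins Three Analogues at the Limit

The compounds below may be only part of what the source reports. "The series", "measured", "known", "first", "only" and "open" are said of these compounds alone.

Three compounds share one core and were measured in an assay for activation of interferon regulatory factor 3 (Homo sapiens), read by a luciferase reporter, with a stated time of 20 h; on this read-out lower numbers stand for an effect already at smaller amounts and higher numbers for an effect only at larger amounts of compound. Compound 1 `CCCn1c(NC(=O)c2ccnn2CC)nc2cc(C(N)=O)cc(OC)c21` gives only a limit of the assay, > 100000 nM. Compound 2 `COc1cc(C(N)=O)cc2nc(NC(=O)c3nccc4ccccc34)n(CCCNC(=O)OCc3ccccc3)c12` likewise gives only a limit, > 100000 nM. Compound 3 `COc1cc(C(N)=O)cc2nc(NC(=O)c3ccccn3)n(CCCNC(=O)OCc3ccccc3)c12` also gives only a limit, > 100000 nM. The step that the two limits leave unreadable from compound 2 to compound 3 therefore cannot be read. Compound 4 `CCn1nccc1C(=O)Nc1nc2cc(C(N)=O)cc(OC)c2n1CCCNC(=O)OCc1ccccc1` differs from compound 3 by 1-ethyl-1H-pyrazol-5-yl in place of pyridin-2-yl on a carbonyl carbon. Among the compounds with values here, no measured step reports a size for this particular change; what bears on it is that compound 1 already carries the same 1-ethyl-1H-pyrazol-5-yl group and sits at the limit together with the others (the limit of > 100000 nM in this assay, at which 3 of the 3 values shown sit). The expected step that the limit leaves unreadable from compound 3 to compound 4 in this assay is none beyond the scatter. Compound 4 is estimated at 150000 nM, between 50000 nM and 600000 nM, and will most likely again be reported only as a limit.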

Compound 4, half-maximal effective concentration: > 100000 nM
Compound 4: a limit, no number; the forecaster's own chance of this, stated with the estimate: 85%; the middle value lies beyond the limit too.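

Compound 4 gives only a limit of the assay, as do compounds 1, 2 and 3, so no step among these four compounds can be read. In this assay the compounds shown leave open which change, if any, would give a measured number.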